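From 3-methoxyphenyl to 4-methoxyphenyl on the amide-type nitrogen

The source may hold more compounds than are shown below. What is called first, only, known or untested is meant among the compounds shown, and "the series" means these compounds.

Three compounds have been measured in a functional assay on HeLa cells (Homo sapiens) for antiproliferative activity, read by sulforhodamine B assay, with a stated time of 72 h; on this read-out lower numbers stand for stronger inhibition and higher numbers for weaker inhibition:

Compound 1 `NC(=S)N/N=C/c1cc2ccccc2s1`: 6770 nM
Compound 2 `COc1cccc(NC(=S)N/N=C/c2ccc3ccccc3n2)c1`: 74500 nM
Compound 3 `Cc1ccc(NC(=O)N/N=C/c2ccc3ccccc3n2)cc1`: > 100000 nM

Of the two compounds that give a number in this assay, compound 2 gives the higher one, and compound 1 gives a lower number by a gap that lies beyond the scatter of the measurement. For compound 3 the result is a limit of the assay rather than a number, as noted in the limit of > 100000 nM in this assay, at which 1 of the 3 values shown sits. No pair among these three differs in a single place, so no measured step can be drawn from them.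

Compound 4 `COc1ccc(NC(=S)N/N=C/c2ccc3ccccc3n2)cc1` differs from compound 2 in one place: 4-methoxyphenyl in place of 3-methoxyphenyl on an amide-type nitrogen. The change keeps all atoms and alters only where the methoxy group sits on the aromatic ring attached to the amide-type nitrogen. Among the compounds with values here, with no measured step of this kind to lean on, the expected step of a 1.2-fold lower number from compound 2 to compound 4 (0.09 log units; within the scatter) from compound 2 to compound 4 in this assay is small, most likely within the scatter, with no clear direction. Compound 4 is therefore expected to give about 60000 nM in this assay, within a range from 20000 nM to 150000 nM.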

Compound 4, half-maximal inhibitory concentration: 72600 nM
The estimate for compound 4 lay 1.2-fold (0.08 log units) below the measured number; the measured number falls inside the stated range.
By their numbers in this assay, from the lowest: compound 1; then compounds 4 and 2 (each within the scatter of the next). At a limit, above all of these: compound 3.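

Moving the methoxy group gives the first measured step among these compounds: in this assay, the change produces a 1.0-fold lower number from compound 2 to compound 4 (0.01 log units; within the scatter). On the aromatic ring carried by the amide-type nitrogen whose other neighbour is the thiocarbonyl carbon, 3-methoxyphenyl and 4-methoxyphenyl therefore cannot be told apart in this assay. The earlier compounds shown here could not show this, since no two of them differed in a single place; here, compound 2 at 74500 nM and compound 4 at 72600 nM show that the placement of this one group leaves the number within the scatter, a finding that holds for this pair alone.

On these data alone, whether a different group at this place, such as an amine, a carboxylic acid or a longer alkoxy chain, would move the number beyond the scatter remains open, as does whether the methoxy placement matters on any other core. Compound 3 gives a limit of the assay rather than a number and differs from compound 2 and compound 4 in more than one place, so it offers no step to set beside this one: the limit of > 100000 nM in this assay, at which 1 of the 4 values shown sits.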